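The compounds below may be only part of what the source reports. "The series", "measured", "known", "first", "only" and "open" are said of these compounds alone.

Measured so far:
- compound 1, `CCCCCCCCCNC(=O)N(Cc1cc(OC)ccc1OC)n1cnnc1`: 29400 nM
- compound 2, `Cc1ccsc1CN(C(=O)Nc1cccc(Cl)c1)n1cnnc1`: > 50000 nM
- compound 3, `COc1ccc(CN(C(=O)Nc2cc(C(F)(F)F)cc(C(F)(F)F)c2)n2cnnc2)cc1OC`: 8540 nM

All three were tested in a functional assay on B16-F10 cells (Mus musculus) for cytotoxicity, read by MTT assay, with a stated time of 48 h; a lower number here means a stronger inhibitor, a higher number a weaker inhibitor. Compound 1 gives 29400 nM, which is the higher of the two numbers recorded, the other being the value of compound 3, 8540 nM, a gap that lies beyond the usual scatter of such measurements. Compound 2 gives only a limit of the assay, > 50000 nM; that is one of the values at the limit of > 50000 nM in this assay, at which 1 of the 3 values shown sits.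

Compound 4, `COc1ccc(OC)c(CN(C(=O)NC2CCCCC2)n2cnnc2)c1`, has not yet been measured. It differs from compound 1 in one place: cyclohexyl in place of nonyl on an amide-type nitrogen. Going by the values given here, no measured pair shows this kind of change, so its effect can only be guessed. The nearest guidance comes from compound 3 with its 8540 nM, but compound 3 differs from compound 1 in several places at once, so it says little about swapping a nonyl for a cyclohexyl. The step from compound 1 to compound 4 is expected to be small, within the scatter or modestly toward a higher number: a 1.2-fold higher number from compound 1 to compound 4 (0.08 log units; within the scatter). Compound 4 is expected to give about 35000 nM, within a range from 12000 nM to 100000 nM, with a fair chance that only a limit is returned.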

Compound 4, half-maximal inhibitory concentration: 39500 nM
For compound 4 the middle estimate is 1.1-fold (0.05 log units) below the measured one; the measured number falls inside the stated range.
By their numbers in this assay, from the lowest: compound 3; then compounds 1 and 4 (each within the scatter of the next). At a limit, above all of these: compound 2.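

In this assay, going by these compounds alone, compounds 1 and 4 form the first pair that differs in one place only, and the step is small: a 1.3-fold higher number from compound 1 to compound 4 (0.13 log units; within the scatter). On this amide-type nitrogen, then, the open nonyl chain and the smaller cyclohexyl ring, with its carbons closed into a six-membered ring, cannot be told apart in this assay, so neither the chain form nor the ring form stands out here. Nothing in the data shown gives a reason for this result.

Still open, from the compounds shown here alone, is whether a group carrying something other than carbon, such as an amine or a carboxylic acid on the chain or ring, or a much shorter chain such as butyl, would move the number beyond the scatter. Compound 3 differs from compound 1 in several places, so its lower number cannot be assigned to any single group.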